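Acid series: halogen swap on the aryl ring

The compounds below may be only part of what the source reports. "The series", "measured", "known", "first", "only" and "open" are said of these compounds alone.

Among the three measured members, compound 3 `O=C(O)C(=O)/C=C(\O)c1cccc(Cl)c1` gives the lowest number: in an assay for inhibition of kynurenine 3-monooxygenase (Rattus norvegicus) (on this read-out higher numbers stand for weaker inhibition and lower numbers for stronger inhibition), compound 3 gives 320 nM. Among the compounds with values here, its methyl ester, compound 1 `COC(=O)C(=O)/C=C(\O)c1cccc(Cl)c1`, gives 1900 nM, and the single step of a 5.9-fold lower number from compound 1 to compound 3 (0.77 log units; beyond the scatter) is the only one-place change measured in the set. Compound 2 `COC(=O)C(=O)/C=C(\O)c1ccc(Cl)c([N+](=O)[O-])c1` differs from compound 1 in several places. In this assay compound 2 gives 11200 nM.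

Compound 4 `O=C(O)C(=O)/C=C(\O)c1cccc(F)c1` keeps the acid of compound 3 and changes only the halogen: fluoro in place of chloro on an aromatic carbon. Within the data shown here, no measured step concerns the halogen on the aromatic ring, and the one step available, the ester-to-acid change, does not bear on it; the aryl substituent has not been varied in isolation. The expectation for compound 4 therefore rests on compound 3 alone, with a modest weakening allowed for the smaller halogen, and is expressed as a 2.5-fold higher number from compound 3 to compound 4 (0.40 log units; beyond the scatter). In this assay compound 4 is estimated at 800 nM, with a range from 250 nM to 2500 nM.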

Compound 4, half-maximal inhibitory concentration: 580 nM
The estimate for compound 4 lay 1.4-fold (0.14 log units) above the measured number; measured number inside the range.
By their numbers in this assay, from the lowest: compounds 3 and 4 (each within the scatter of the next); then compound 1; then compound 2.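

Within the data shown here, in the acid series, the only step on the halogen (a 1.8-fold higher number from compound 3 to compound 4 (0.26 log units; within the scatter)) lies within the scatter in this assay, so chloro and fluoro cannot be told apart at this place, on an aromatic carbon meta to a group of 8 heavy atoms. The earlier step (a 5.9-fold lower number from compound 1 to compound 3 (0.77 log units; beyond the scatter)) lies beyond the scatter but concerns the methyl ester and the acid, and it says nothing about the halogen. Nothing available offers an explanation for this result.

Still open, from the compounds shown here alone, is whether a larger group at the same place, such as bromo, methoxy or trifluoromethyl, or plain hydrogen there, would stay within the scatter of compound 3. Also open, going by these compounds, is whether fluoro in place of chloro would give a similar step in the methyl ester, or with an amide in place of the acid.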